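The compounds below may be only part of what the source reports. "The series", "measured", "known", "first", "only" and "open" are said of these compounds alone.

Among the compounds with values here, compound 1 `Cn1cc(-c2cnc(NCc3c(F)ccc4c3CCO4)c3cn[nH]c(=O)c23)cn1` is one of three compounds measured in a physicochemical assay for solubility, read by LC-MS, in phosphate buffer, with a stated time of 24 h, at pH 7.4 (on this read-out lower numbers stand for lower solubility and higher numbers for higher solubility), and in this assay compound 1 gives 1000 nM. That is the lowest of the three numbers. Compound 2 `COCCC(=O)Nc1cnc(NCc2c(F)ccc3c2CCO3)n2cnnc12` gives 980000 nM in this assay, and compound 3 `CN(C(=O)c1ccccc1)c1cnc(NCc2c(F)ccc3c2CCO3)n2cnnc12` gives 280000 nM. Both sit far above compound 1, which stands apart from them, with compound 3 the nearer and compound 2 the further of the two.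

Within the data shown here, the single step measured so far runs between compound 2 and compound 3: a 3.5-fold lower number from compound 2 to compound 3 (0.54 log units; beyond the scatter). Compound 4 `CNC(=O)c1ncc(-c2cnc(NCc3c(F)ccc4c3CCO4)c3cn[nH]c(=O)c23)n1C` is now to be measured in this assay. It differs from compound 1 in one place: 1-methyl-2-(methylcarbamoyl)-1H-imidazol-5-yl in place of 1-methyl-1H-pyrazol-4-yl on an aromatic carbon. The measured step from compound 2 to compound 3 concerns another core and another kind of exchange, so it does not bear directly on the change from compound 1 to compound 4. Among the measured compounds shown here, no measured step speaks to a pyrazole replaced by an imidazole carrying a carboxamide. With nothing to anchor a direction, the expected step in this assay is a 2.0-fold higher number from compound 1 to compound 4 (0.30 log units; within the scatter), small and not clearly beyond the scatter. Compound 4 is therefore estimated at 2000 nM in this assay, with a range from 500 nM to 8000 nM.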

Compound 4, solubility: 5000 nM
Beside the measured number, compound 4's estimate is 2.5-fold (0.40 log units) below it, within the range that was stated.
By their numbers in this assay, from the lowest: compound 1; then compound 4; then compound 3; then compound 2.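

At the aromatic carbon para to a large group on the core of compound 1, this assay responds to the exchange of 1-methyl-1H-pyrazol-4-yl for 1-methyl-2-(methylcarbamoyl)-1H-imidazol-5-yl, with a 5.0-fold higher number from compound 1 to compound 4 (0.70 log units; beyond the scatter). Within the data shown here, this is the first measured step on this core, and it shows that a group of 10 heavy atoms, carrying 1 hydrogen-bond donor, can replace one of 6 heavy atoms with no donor at this place without the number falling, though the step is only modest. No measurement available here accounts for the rise.

From the compounds shown here alone, whether the rise belongs to the methylcarbamoyl group or to the exchange of the ring itself stays open, and the plain 1-methyl-1H-imidazol-5-yl group at this place would separate the two. Also open, going by these compounds, is how this assay would read with a carboxylic acid or an amine in place of the methylcarbamoyl group on the same ring, so the step from compound 1 to compound 4 stands as a single point at this position rather than as a trend.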